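The compounds below may be only part of what the source reports. "The series", "measured", "known", "first", "only" and "open" are said of these compounds alone.

Compound 1 `Cn1cccc1-c1cc(-c2ccc(Br)cc2)[nH]c(=O)c1C#N` gives 34700 nM in a functional assay on HOP-62 cells (Homo sapiens) for cytotoxicity, read by sulforhodamine B assay, with a stated time of 48 h (a higher number here means a weaker inhibitor of growth, a lower number a stronger inhibitor of growth), the only number among the two results shown, so it stands alone as a measured value. Compound 2 `COc1ccc(-c2cc(-c3cccs3)[nH]c(=O)c2C#N)cc1` reaches only a limit of > 100000 nM in this assay, a limit recorded as the limit of > 100000 nM in this assay, at which 1 of the 2 values shown sits. Compound 3 `Cn1cccc1-c1cc(-c2ccc(Br)cc2)n(C(=S)Nc2ccc(F)cc2)c(=O)c1C#N` differs from compound 1 by a group of 10 heavy atoms (7 carbon, 1 nitrogen, 1 fluorine, 1 sulfur; one six-membered aromatic ring of carbon only) in place of a hydrogen atom, on an aromatic nitrogen. Going by the values given here, no measured pair shows a change of this kind, so the step from compound 1 to compound 3 is expected to be a 1.7-fold lower number from compound 1 to compound 3 (0.24 log units; within the scatter), a shift of uncertain direction and probably modest in size. Compound 3 is therefore expected to give about 20000 nM in this assay, within a range from 5000 nM to 80000 nM.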

Compound 3, concentration for 50% growth inhibition: 37100 nM
The estimate for compound 3 lay 1.9-fold (0.27 log units) below the measured number, and the stated range covers the measured number.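

The earlier compounds shown here held no step at this aromatic nitrogen. Putting the group with its six-membered aromatic ring in place of the hydrogen atom gives a 1.1-fold higher number from compound 1 to compound 3 (0.03 log units; within the scatter) in this assay, so a group of this size can stand here with the two values within the scatter of each other. No result shown gives a reason for this. From the compounds shown here alone, whether a methyl group or a chain ending in an amine on this nitrogen would move the value beyond the scatter remains open.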